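Replacing a Piperidine Ring with a Fluorinated Acid Chain

The compounds below may be only part of what the source reports. "The series", "measured", "known", "first", "only" and "open" are said of these compounds alone.

Compound 1 `COC(=O)C1=C(CN2CCCCC2)NC(c2nccs2)=NC1(C)c1ccc(F)cc1` was measured in an ADME assay on microsomes from liver (Mus musculus) for metabolic stability, read by LC-MS, using NADPH, with stated times of 10 min and 30 min, tested at 1 uM (on this read-out lower numbers stand for slow clearance and higher numbers for fast clearance), and gives 88 mL/min/kg. Its only companion so far is compound 2 `COC(=O)C1=C(CN2CCOCC2=O)NC(c2nccs2)=NC1(C)c1ccc(F)cc1`, which in this assay gives 80 mL/min/kg; the two numbers sit side by side, as the step of a 1.1-fold lower number from compound 1 to compound 2 (0.04 log units; within the scatter) shows. Compound 3 `COC(=O)C1=C(COC(C(=O)O)C(F)(F)F)NC(c2nccs2)=NC1(C)c1ccc(F)cc1` is the next candidate. Compared with compound 1 it carries a group of 9 heavy atoms (3 carbon, 3 oxygen, 3 fluorine; no ring) in place of a group of 6 heavy atoms (5 carbon, 1 nitrogen; one six-membered non-aromatic ring with 1 hetero atom), on a saturated chain carbon bound to a double-bonded ring carbon. Among the compounds with values here, the single measured step that bears on this change is the swap at the same place from compound 1 to compound 2, which stayed within the scatter. Within the data shown here, no measured compound carries anything resembling the entering group, so the expectation leans on that one step alone. The step of a 1.3-fold lower number from compound 1 to compound 3 (0.10 log units; within the scatter) is therefore expected to be small, with a wide band of uncertainty. For compound 3 in this assay the estimate is 70 mL/min/kg, with a range from 35 mL/min/kg to 120 mL/min/kg.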

Compound 3, clearance: 24 mL/min/kg
The estimate for compound 3 lay 2.9-fold (0.46 log units) above the measured number; the whole stated range lies above it.
By their numbers in this assay, from the lowest: compound 3; then compounds 2 and 1 (each within the scatter of the next).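

At this place, on a saturated chain carbon bound to a double-bonded ring carbon, exchanging one ring for another gave no step beyond the scatter in this assay, but the open chain of compound 3 does, with a 3.7-fold lower number from compound 1 to compound 3 (0.56 log units; beyond the scatter) and with a 3.3-fold lower number from compound 2 to compound 3 (0.52 log units; beyond the scatter) in the same read-out. The clearance number at this place can therefore respond to the group attached there, whichever of the two rings leaves. Nothing measured here accounts for the drop.

The entering chain brings an ether oxygen, a trifluoromethyl group and a carboxylic acid together, so the compounds shown cannot say which of these parts goes with the lower number. Also open, from the compounds shown here alone, is how a chain keeping the trifluoromethyl group but ending in a primary amide, or one keeping the carboxylic acid without the trifluoromethyl group, would compare.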